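Cytotoxicity Forecast for a Dimethylfuranyl Replacement on the Carbonyl

The source may report more compounds than this note shows. Statements on the series, on what has been measured and on what is new or still open speak of the compounds shown alone.

Compound 1: `O=C1c2ccccc2C(=O)N1CCOC(=S)N(C(=O)c1ccccc1[N+](=O)[O-])c1ccc(Cl)cc1` — 21000 nM
Compound 2: `Cc1cccc(C(=O)N(C(=S)OCCN2C(=O)c3ccccc3C2=O)c2ccc(Cl)cc2)c1` — 58000 nM

Both measured compounds were tested in an ADME assay on MT4 cells (Homo sapiens) for cytotoxicity, read by MTT assay; a lower number here means that less compound is tolerated, a higher number that more compound is tolerated. Compound 2 stands highest of the two numbers; its nearest neighbour is compound 1, and the step of a 2.8-fold higher number from compound 1 to compound 2 (0.44 log units; beyond the scatter) lies beyond the scatter. Compound 3, `Cc1cc(C(=O)N(C(=S)OCCN2C(=O)c3ccccc3C2=O)c2ccc(Cl)cc2)c(C)o1`, has not yet been measured. It differs from compound 2 in one place: 2,5-dimethylfuran-3-yl in place of 3-methylphenyl on a carbonyl carbon. For the measured compounds named here, the only measured step that bears on this change is a 2.8-fold higher number from compound 1 to compound 2 (0.44 log units; beyond the scatter), which also exchanged the group on the same carbonyl carbon and moved the number only modestly. A single step with a different pair of groups is thin ground, so the account expects at most a small shift for compound 3 in this assay, in either direction, most likely within the scatter. Compound 3 is therefore estimated at 50000 nM, with a range from 20000 nM to 120000 nM, which is expected to amount to a step of a 1.2-fold lower number from compound 2 to compound 3 (0.06 log units; within the scatter).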

Compound 3, half-maximal cytotoxic concentration: 40000 nM
Beside the measured number, compound 3's estimate is 1.3-fold (0.10 log units) above it; measured number inside the range.
By their numbers in this assay, from the lowest: compounds 1, 3 and 2 (each within the scatter of the next, the first and the last beyond it).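

In this assay, the five-membered aromatic ring with 1 hetero atom stands on this carbonyl carbon in place of the six-membered aromatic ring of carbon only, and the exchange of 3-methylphenyl for 2,5-dimethylfuran-3-yl gives a 1.5-fold lower number from compound 2 to compound 3 (0.16 log units; within the scatter) without leaving the scatter. The exchange of 2-nitrophenyl for the same group gives a 1.9-fold higher number from compound 1 to compound 3 (0.28 log units; within the scatter) and is also within the scatter, so compound 3 cannot be told apart from either compound 1 or compound 2, even though those two are separated by a step beyond it. Nothing available accounts for these numbers.

The compounds shown leave open whether a carboxylic acid or an amine on the group at this carbonyl carbon would give a step beyond the scatter. They also leave open whether a saturated cyclohexyl ring or a longer alkyl chain would be tolerated alike here.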